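This account rests on a few compounds, and the source may have more. Where it says the series, first, only, none or still open, it means among the compounds named here.

The measured compounds:
compound 1, `O=C1NC(c2ccc(Br)cc2)CN1S(=O)(=O)c1ccc(Cl)cc1`, gave 161000 nM in a functional assay on A549 cells (Homo sapiens) for cytotoxicity; on this read-out lower numbers stand for stronger inhibition and higher numbers for weaker inhibition.
compound 2, `Cc1ccc(C2CN(S(=O)(=O)c3ccc(Cl)cc3)C(=O)N2)cc1`, gave 158000 nM in this assay.
compound 3, `Cc1ccc(C2CNC(=O)N2S(=O)(=O)c2ccc3c(c2)CCC3)cc1`, gave 90300 nM in this assay.

All three values sit within the usual scatter of one another, so none of them can be called stronger or weaker than the others. Compound 2 and compound 1 share one core and differ in a single place, (bromo in place of methyl on an aromatic carbon); the measured step was a 1.0-fold higher number from compound 2 to compound 1 (0.01 log units; within the scatter). Compound 3 carries a different core, and the difference between the two cores is not broken down here. That second core is also found in the unmeasured compound 4, `O=C1NCC(c2ccc(Br)cc2)N1S(=O)(=O)c1ccc2c(c1)CCC2`. The change from compound 3 to compound 4 is bromo in place of methyl on an aromatic carbon, the same change as from compound 2 to compound 1, made at the same place on the ring.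

The step from compound 3 to compound 4 is expected to be a 1.0-fold higher number from compound 3 to compound 4 (0.01 log units; within the scatter) in this assay, again within the scatter. Among the compounds with values here, this expectation rests on the one earlier step, a 1.0-fold higher number from compound 2 to compound 1 (0.01 log units; within the scatter), and on compound 3 giving 90300 nM. Compound 4 is therefore estimated at 92000 nM, with a range from 46000 nM to 184000 nM.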

Compound 4, half-maximal inhibitory concentration: > 237000 nM
Compound 4: a limit, no number (the forecaster's own chance of this, stated with the estimate: 5%); middle value at least 2.5-fold (0.41 log units) away from the limit.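

In this assay compound 4 gives > 237000 nM, which is a limit of the assay and not a number. Bromo in place of methyl, the change from a 4-methylphenyl to a 4-bromophenyl group, gives an at least 2.6-fold higher number from compound 3 to compound 4 (0.41 log units; beyond the scatter) on one core, while on the other core it gives a 1.0-fold higher number from compound 2 to compound 1 (0.01 log units; within the scatter). So the change moves the number beyond the scatter on one core and not on the other, yet this does not show that the two cores truly respond differently: the same change on two cores in this assay, a 1.0-fold higher number (0.01 log units; within the scatter) from compound 2 to compound 1 and an at least 2.6-fold higher number (0.41 log units; beyond the scatter) from compound 3 to compound 4; the limit leaves it open whether they differ.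

With only these two pairs, the compounds shown leave open whether the same change would read the same way on a third core. They also leave open how other groups on an aromatic carbon at this same place, such as fluoro, methoxy or a carboxylic acid, would compare with methyl and bromo on either core.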